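This account rests on a few compounds, and the source may have more. Where it says the series, first, only, none or still open, it means among the compounds named here.

Compound 1, `CC(C)Nc1ccc(-c2ccn3c(CC4CC4)nnc3c2C(F)(F)F)cc1F`, gives 93.3 nM in a functional assay on cells for positive allosteric modulation of metabotropic glutamate receptor 2 (Homo sapiens), read by scintillation counting and GTPgammaS binding, with a stated time of 30 min; a lower number here means that less compound is needed, a higher number that more compound is needed for the effect.
Compound 2, `CC(C)Nc1ccc(-c2ccn3c(CC4CC4)nnc3c2C(F)(F)F)cc1Cl`, gives 17.4 nM in this assay.
Compound 3, `COc1ccc(COc2ccc(-c3ccn4c(CC5CC5)nnc4c3C(F)(F)F)cc2F)cn1`, gives 40.7 nM in this assay.

Compound 2 has the lowest number of the three, with compound 3 nearest and compound 1 furthest. Compound 4, `O[C@H]1CC[C@H](Oc2ccc(-c3ccn4c(CC5CC5)nnc4c3C(F)(F)F)cc2Cl)CC1`, differs from compound 2 by (4-hydroxycyclohexyl)oxy in place of isopropylamino on an aromatic carbon. The step that bears on this is a 2.3-fold lower number from compound 1 to compound 3 (0.36 log units; beyond the scatter), where an ether likewise replaced the isopropylamino group; the step of a 5.4-fold lower number from compound 1 to compound 2 (0.73 log units; beyond the scatter) only sets the chloro series in which compound 4 sits. From that one precedent a small lowering or no change beyond the scatter is expected in this assay, so for compound 4 the expected step is a 1.5-fold lower number from compound 2 to compound 4 (0.16 log units; within the scatter). Compound 4 is therefore estimated at 12 nM, within 4 nM to 40 nM.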

Compound 4, half-maximal effective concentration: 25.1 nM
Beside the measured number, compound 4's estimate is 2.1-fold (0.32 log units) below it, and the stated range covers the measured number.
By their numbers in this assay, from the lowest: compounds 2, 4 and 3 (each within the scatter of the next, the first and the last beyond it); then compound 1.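

In this assay, the step to the larger (4-hydroxycyclohexyl)oxy group, with its six-membered non-aromatic ring and two defined stereocentres, is a 1.4-fold higher number from compound 2 to compound 4 (0.16 log units; within the scatter), so swapping isopropylamino for this group leaves the number unchanged within the scatter. This position, ortho to a chloro group, therefore accepts an ether carrying a saturated carbon ring without a measurable change. No measured property on hand explains this result. Still open, on these data alone, are the other stereoisomer of this group and whether an amine or a carboxylic acid in place of its hydroxyl would give the same result.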